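The source may report more compounds than this note shows. Statements on the series, on what has been measured and on what is new or still open speak of the compounds shown alone.

In a functional assay on A549 cells (Homo sapiens) for antiproliferative activity, read by MTT assay, with a stated time of 48 h (a higher number here means a weaker inhibitor, a lower number a stronger inhibitor), compound 1 `COc1ccc(-c2nc3cccc(-c4cc(OC)c(OC)c(OC)c4)c3o2)cc1OC` gives 2800 nM, compound 2 `COc1cc(-c2cccc3nc(-c4ccc(C)cc4)oc23)cc(OC)c1OC` gives 680 nM and compound 3 `COc1cc(-c2cccc3nc(-c4cccc(C)c4)oc23)cc(OC)c1OC` gives 16700 nM, the highest number of the three. Compound 4 `COc1cc(-c2cccc3nc(-c4ccc(N)cc4)oc23)cc(OC)c1OC` carries 4-aminophenyl in place of the 3-methylphenyl of compound 3: 4-aminophenyl in place of 3-methylphenyl on an aromatic carbon. The most telling measured change is a 25-fold higher number from compound 2 to compound 3 (1.39 log units; beyond the scatter), a large step between 4-methylphenyl and 3-methylphenyl. The modest steps of a 4.1-fold lower number from compound 1 to compound 2 (0.61 log units; beyond the scatter) and a 6.0-fold higher number from compound 1 to compound 3 (0.78 log units; beyond the scatter) show the same group position responding in both directions. Going by the values given here, no measured compound carries the amino group, so the reading from compound 2 is uncertain. In this assay, a large step to a lower number is expected, a 14-fold lower number from compound 3 to compound 4 (1.14 log units; beyond the scatter). For compound 4 the estimated value is 1200 nM, within an expected range of 250 nM to 6000 nM.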

Compound 4, half-maximal inhibitory concentration: 720 nM
Compound 4: the middle estimate sits 1.7-fold (0.22 log units) above what was measured; low and high end bracket the measured number.
By their numbers in this assay, from the lowest: compounds 2 and 4 (each within the scatter of the next); then compound 1; then compound 3.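

In this assay, amino in place of methyl on the phenyl group gives a 1.1-fold higher number from compound 2 to compound 4 (0.02 log units; within the scatter), so the two groups cannot be told apart here. 4-Aminophenyl also gives a 3.9-fold lower number from compound 1 to compound 4 (0.59 log units; beyond the scatter) and a 23-fold lower number from compound 3 to compound 4 (1.37 log units; beyond the scatter), so a second group with its substituent at the 4 place sits well clear of 3-methylphenyl, though that last step changes both the substituent and where it sits. Nothing at hand explains these numbers.

On these data alone, it remains open whether 3-aminophenyl would match 3-methylphenyl or 4-aminophenyl. Also open, as far as these compounds go, is how a 4-hydroxyphenyl or a 4-carboxyphenyl would read here.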